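The compounds below may be only part of what the source reports. "The series", "measured", "known", "first", "only" and "open" are said of these compounds alone.

Working notes on the series. Of the compounds shown here, two have been measured in an assay on isolated protein for inhibition of Dihydrofolate reductase (Homo sapiens), read by spectrophotometry, using NADPH, with a stated time of 10 min; a higher number here means a weaker inhibitor, a lower number a stronger inhibitor. Compound 1 `Cc1cc2ncn(-c3ccc4c(N)nc(N)nc4c3)c2cc1C` gives 1610 nM. Compound 2 `Cc1cc2nc(-c3cncn3C)n(-c3ccc4c(N)nc(N)nc4c3)c2cc1C`, which carries 1-methyl-1H-imidazol-5-yl in place of hydrogen on an aromatic carbon of the shared core, gives 2920 nM. The step of a 1.8-fold higher number from compound 1 to compound 2 (0.26 log units; within the scatter) is within the scatter, so on the numbers shown compound 1 does not stand apart from compound 2; the two are effectively level.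

Compound 3 `COc1ccc(-c2nc3cc(C)c(C)cc3n2-c2ccc3c(N)nc(N)nc3c2)cc1` has not yet been measured in this assay. Relative to compound 1 the change is 4-methoxyphenyl in place of hydrogen on an aromatic carbon. Going by the values given here, the only measured step that bears on this is the one that likewise replaces hydrogen on an aromatic carbon of the core with an aromatic group, a 1.8-fold higher number from compound 1 to compound 2 (0.26 log units; within the scatter), and it did not move the number beyond the scatter. Among the compounds with values here, since that is the single comparison available, the expected step of a 1.6-fold higher number from compound 1 to compound 3 (0.19 log units; within the scatter) for compound 3 is likewise estimated to fall within the scatter, with no clear direction. Compound 3 is therefore expected to give about 2500 nM in this assay, with a range of 900 nM to 7000 nM.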

Compound 3, inhibition constant: 2300 nM
Estimate against measurement, compound 3: 1.1-fold (0.04 log units) above; low and high end bracket the measured number.
By their numbers in this assay, from the lowest: compounds 1, 3 and 2 (each within the scatter of the next).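

At the aromatic carbon between two ring nitrogen atoms, the series now has a second aromatic group, and this one is a six-membered aromatic ring of carbon only: in this assay the step to 4-methoxyphenyl is (a 1.4-fold higher number from compound 1 to compound 3 (0.15 log units; within the scatter)). Exchanging one aromatic group for the other at this same position gives (a 1.3-fold lower number from compound 2 to compound 3 (0.10 log units; within the scatter)), so the assay does not separate 4-methoxyphenyl from 1-methyl-1H-imidazol-5-yl, and hydrogen, 1-methyl-1H-imidazol-5-yl and 4-methoxyphenyl all lie within the scatter of the next in order. No measurement is at hand that would account for this flat response.

From the compounds shown here alone, both groups placed here so far are aromatic rings, so it remains open whether an amine, a carboxylic acid or a longer alkyl chain on this carbon would give a number beyond the scatter from compound 1. The three compounds also share the rest of the core, including its methyl groups, and so they do not show how the number responds to a change anywhere else on it.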